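The source may hold more compounds than are shown below. What is called first, only, known or untested is meant among the compounds shown, and "the series" means these compounds.

Compound 1, with the structure `Cn1cnc2c(Nc3ccccc3)ncnc21`, and compound 2, with the structure `Cn1cnc2c(Nc3ccc(F)cc3)ncnc21`, share one core and differ only by fluoro in place of hydrogen on an aromatic carbon. In an assay on isolated protein for inhibition of Rho-associated protein kinase 1 (Homo sapiens), tested at 30 uM (on this read-out lower numbers stand for less inhibition and higher numbers for more inhibition at the one concentration tested (going by the name of the read-out)), compound 1 gives 0%, and in this assay compound 2 gives 7%; the step of a number 7 percentage points higher from compound 1 to compound 2 (within the scatter) is too small to count as a real difference between them. Compound 3, with the structure `Cn1c(-c2ccc([S+](C)[O-])cc2)nc2c(Sc3ccccc3)ncnc21`, is built on a different core; how the two cores differ is not broken down here. In this assay compound 3 gives 1%, a number that sits close to those of compound 1 and compound 2. Compound 4, with the structure `Cn1c(-c2ccc([S+](C)[O-])cc2)nc2c(Sc3ccc(F)cc3)ncnc21`, has not yet been tested and differs from compound 3 by fluoro in place of hydrogen on an aromatic carbon, the same change that was made from compound 1 to compound 2. The expected step of a number 3 percentage points higher from compound 3 to compound 4 (within the scatter) rests on the earlier step of a number 7 percentage points higher from compound 1 to compound 2 (within the scatter), which was too small to matter, so the new core is not expected to change that picture on its own. Compound 4 is therefore estimated at 4% in this assay, with a range from 0% to 15%, before the measurement is known.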

Compound 4, a percentage reported as inhibition, at one concentration (the size of the read-out at that concentration, not a potency): 0%
Compound 4: the middle estimate sits 4 percentage points above what was measured; the range from low to high includes it.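

In this assay, the fluoro group gives a number 1 percentage points lower from compound 3 to compound 4 (within the scatter), so on this core, as on the core of compound 1, the change makes no difference that can be told apart from ordinary scatter. Set side by side, the two steps do not differ in any way this read-out can detect: the same change on two cores in this assay, a number 7 percentage points higher (within the scatter) from compound 1 to compound 2 and a number 1 percentage points lower (within the scatter) from compound 3 to compound 4, 8 percentage points apart, within the scatter of two such steps

This shows that the swap of hydrogen for fluoro leaves no real mark on either core, but all four compounds give only small numbers, so the agreement is one of two near-empty results. It does not show that the change would carry over in the same way to a compound with clear inhibition.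

The compounds shown leave open whether a different group at the same place on the ring, such as an amine or a carboxylic acid, would give a clearly higher number. They also leave open which part of the difference between the two cores matters, if any does.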